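A few compounds are considered here, and "the series" means these few. Any claim that something is new, unique, unknown or untested is made for them only; others in the source may bear on it.

Compound 1 `NCCNc1c(C(=O)NCc2ccc(F)cc2)nc(Br)c2cccnc12` shows the shared core of this small set, and in a functional assay on HCT-116 cells (Homo sapiens) for cytotoxicity, read by MTT assay, with a stated time of 72 h (a higher number here means a weaker inhibitor, a lower number a stronger inhibitor), compound 1 gives only a limit, > 20000 nM. Compound 2 `N[C@H]1CC[C@H](Nc2c(C(=O)NCc3ccc(F)cc3)nc(Br)c3cccnc23)CC1` puts 4-aminocyclohexyl in place of 2-aminoethyl on the ring nitrogen substituent, and in this assay compound 2 gives 4000 nM, which is an at least 5.0-fold lower number from compound 1 to compound 2 (0.69 log units; beyond the scatter). Compound 3 `Cc1ccc(S(=O)(=O)Oc2c(C(=O)NCc3ccc(F)cc3)nc(Br)c3cccnc23)cc1` carries ((4-methylphenyl)sulfonyl)oxy on the same aromatic carbon. In this assay compound 3 gives only a limit, > 20000 nM. Compound 3 therefore stands at the limit of > 20000 nM in this assay, at which 2 of the 3 values shown sit; the step from compound 2 is an at least 5.0-fold higher number from compound 2 to compound 3 (0.69 log units; beyond the scatter), whereas there is a step that the two limits leave unreadable from compound 1 to compound 3.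

Compound 4 `CNc1c(C(=O)NCc2ccc(F)cc2)nc(Br)c2cccnc12` differs from compound 3 by methylamino in place of ((4-methylphenyl)sulfonyl)oxy on an aromatic carbon. Within the data shown here, two measured steps bear on this. The step from compound 2 to compound 3 shows that removing the amino-bearing substituent and installing the sulfonyl ester costs potency, so a return to a nitrogen substituent could recover some of it. Yet compound 1, whose nitrogen substituent carries a further amine, sits at the limit, and the small methylamino of compound 4 lacks that amine. He therefore expects compound 4 to gain modestly at best, an at least 1.3-fold lower number from compound 3 to compound 4 (0.12 log units; that floor lies within the scatter), with a real chance that only a limit is reported, and estimates compound 4 at 15000 nM, within 5000 nM to 40000 nM.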

Compound 4, half-maximal inhibitory concentration: > 20000 nM
Compound 4: no number, only a limit; the forecaster's own chance of this, stated with the estimate: 55%; middle value at least 1.3-fold (0.12 log units) from the limit.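

Compound 4 gives only a limit in this assay, and it joins the other compounds that do so: the limit of > 20000 nM in this assay, at which 3 of the 4 values shown sit. Compound 1 had already shown that a nitrogen on this aromatic carbon does not ensure a readable value, and methylamino, with only 2 heavy atoms, now shows the same for a much smaller substituent, leaving compound 2 as the only compound with a number. Putting methyl in place of 4-aminocyclohexyl on that nitrogen gives an at least 5.0-fold higher number from compound 2 to compound 4 (0.69 log units; beyond the scatter), while the steps to compound 4 from compound 1 and compound 3 cannot be read, as both ends of each are limits.

The compounds shown leave open whether the value of compound 2 depends on the cyclohexyl part of 4-aminocyclohexyl or on its amine, a question that a plain cyclohexyl group or a 4-hydroxycyclohexyl group would separate. They also leave open how a longer chain with a terminal amine, such as 4-aminobutyl, would compare on the same nitrogen.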